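Methoxy in Place of Hydrogen on a Silent Core

This account rests on a few compounds, and the source may have more. Where it says the series, first, only, none or still open, it means among the compounds named here.

Three measured compounds share one core. Compound 3 `c1ccc2c(c1)CCC2c1ncc[nH]1` is that core with hydrogen on the aromatic carbon in question. In a functional assay on CHO cells for agonist activity at Alpha-1B adrenergic receptor (Homo sapiens), read by FLIPR and calcium flux (a higher number here means that more compound is needed for the effect, a lower number that less compound is needed), compound 3 reaches only the limit of the assay, reported as > 10000 nM, so no number is known for it. Compound 1 `CCS(=O)(=O)Nc1cccc2c1CCC2c1ncc[nH]1` carries an (ethylsulfonyl)amino group on an aromatic carbon, and in this assay compound 1 likewise gives only the limit > 10000 nM. Compound 2 `c1ccc(-c2cccc3c2CCC3c2ncc[nH]2)nc1` carries a pyridin-2-yl group on an aromatic carbon, and in this assay compound 2 again gives only the limit > 10000 nM. The three steps among them, a step that the two limits leave unreadable from compound 1 to compound 2, a step that the two limits leave unreadable from compound 1 to compound 3 and a step that the two limits leave unreadable from compound 2 to compound 3, therefore carry no readable size, because of the limit of > 10000 nM in this assay, at which 3 of the 3 values shown sit.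

Compound 4 `COc1cccc2c1CCC2c1ncc[nH]1` differs from compound 3 in one place: methoxy in place of hydrogen on an aromatic carbon. Going by the values given here, none of the measured steps reads as a gain or a loss, so nothing in this set points to a step in this assay in either direction beyond the scatter. The expected step that the limit leaves unreadable from compound 3 to compound 4 is thus an estimate without direction. Compound 4 is expected to give about 15000 nM in this assay, within a range of 3000 nM to 60000 nM, most likely again as a limit.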

Compound 4, half-maximal effective concentration: > 10000 nM
Compound 4 ended at the assay's limit (the forecaster's own chance of this, stated with the estimate: 75%); the middle value is on the limit's open side.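

No step from compound 4 to compound 1, compound 2 or compound 3 can be read in this assay, because each gives only a limit and not a number: the limit of > 10000 nM in this assay, at which 4 of the 4 values shown sit.

The compounds shown leave open how much compound any of these four would need for an effect, and whether any group at this place on the shared core changes that need.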